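This account rests on a few compounds, and the source may have more. Where it says the series, first, only, none or still open, it means among the compounds named here.

Measured compounds:
- compound 1, `N#Cc1ccc(Nc2nc(Oc3ccccc3Cl)c3ccccc3n2)cc1`: 38000 nM
- compound 2, `CCOc1cc(C#N)cc(Cl)c1Oc1nc(Nc2ccc(C#N)cc2)nc2ccccc12`: 22000 nM
- compound 3, `Cc1cc(Br)cc(Br)c1Oc1nc(Nc2ccc(C#N)cc2)nc2ccccc12`: 150000 nM

In an ADME assay on MT4 cells (Homo sapiens) for cytotoxicity, read by MTT assay, with a stated time of 4 days (a higher number here means that more compound is tolerated, a lower number that less compound is tolerated), compound 1 stands second highest of the three numbers. Its nearest neighbour is compound 2, whose value of 22000 nM lies within the scatter of that of compound 1, so the two cannot be told apart. Going by the values given here, compound 3 stands furthest away, and the step of a 3.9-fold higher number from compound 1 to compound 3 (0.60 log units; beyond the scatter) is the only one between measured compounds that differ in one place.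

Compound 4, `N#Cc1ccc(Nc2nc(Oc3ccc(F)cc3)c3ccccc3n2)cc1`, has not yet been measured. It differs from compound 1 in the group on the oxygen: 4-fluorophenyl in place of 2-chlorophenyl on an oxygen on an aromatic ring

Among the compounds with values here, the one measured step that bears on this change is a 3.9-fold higher number from compound 1 to compound 3 (0.60 log units; beyond the scatter), where the group on the same oxygen was replaced by a larger, more substituted ring, and the number rose by a modest amount. The exchange from compound 1 to compound 4 keeps a single halogen on a ring of the same size, so a smaller shift is expected than in that step, and the expectation is that the move from compound 1 to compound 4, a 1.1-fold higher number from compound 1 to compound 4 (0.02 log units; within the scatter), stays within the scatter. In this assay compound 4 is therefore estimated at 40000 nM, with a range from 15000 nM to 110000 nM.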

Compound 4, half-maximal cytotoxic concentration: > 351000 nM
Compound 4: only a limit was reported (the forecaster's own chance of this, stated with the estimate: 10%); at least 8.7-fold (0.94 log units) between middle value and limit.
By their numbers in this assay, from the lowest: compounds 2 and 1 (each within the scatter of the next); then compound 3. At a limit, above all of these: compound 4.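

Compound 4 is reported in this assay only as a limit and not as a number: the limit of > 351000 nM in this assay, at which 1 of the 4 values shown sits.

The exchange of 2-chlorophenyl for 4-fluorophenyl on this oxygen gives an at least 9.2-fold higher number from compound 1 to compound 4 (0.96 log units; beyond the scatter) even though the two groups match in heavy atoms and in their single aromatic ring, so the group here can move the number without any change in its size. Going by these compounds alone, compound 3 had stood highest of the earlier compounds, yet the exchange of its 2,4-dibromo-6-methylphenyl for 4-fluorophenyl gives an at least 2.3-fold higher number from compound 3 to compound 4 (0.36 log units; beyond the scatter) and so the more heavily substituted ring does not carry the highest tolerance among the compounds that differ at this oxygen.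

The compounds shown do not separate the kind of halogen from its place on the ring, for both change together in this exchange. On these data alone, how a plain phenyl or a 4-chlorophenyl group on the same oxygen would stand in this assay remains open, and so does the actual number of compound 4.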